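The source may report more compounds than this note shows. Statements on the series, on what has been measured and on what is new or still open speak of the compounds shown alone.

In a functional assay, read by spectrophotometry, with a stated time of 30 min (a lower number here means a stronger inhibitor, a higher number a weaker inhibitor), three compounds that share one core have been measured. Compound 1 `Cc1nc2c3ccccc3ccc2c2nc3c(ccc4ccccc43)c(-c3cccc4ccccc34)c12` gives 111 ug/mL. Compound 2 `Cc1nc2c3ccccc3ccc2c2nc3c(ccc4ccccc43)c(-c3cc([N+](=O)[O-])ccc3N)c12` gives 93.1 ug/mL. Compound 3 `Cc1nc2c3ccccc3ccc2c2nc3c(ccc4ccccc43)c(-c3ccccc3Cl)c12` gives 118 ug/mL. Compound 2 therefore cannot be told apart from the other two, since its steps to both stay within the scatter.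

Compound 4 `Cc1nc2c3ccccc3ccc2c2nc3c(ccc4ccccc43)c(-c3ccc(O)cc3)c12` has not yet been measured. It differs from compound 2 in one place: 4-hydroxyphenyl in place of 2-amino-5-nitrophenyl on an aromatic carbon.

Three measured steps exchange the group at this same carbon: a 1.2-fold lower number from compound 1 to compound 2 (0.08 log units; within the scatter), a 1.1-fold higher number from compound 1 to compound 3 (0.03 log units; within the scatter) and a 1.3-fold higher number from compound 2 to compound 3 (0.10 log units; within the scatter). All three are small and lie within the scatter. Among the compounds with values here, on that evidence, no step beyond the scatter is expected in this assay in either direction, although no measured compound yet carries 4-hydroxyphenyl. The expected change is a 1.1-fold higher number from compound 2 to compound 4 (0.05 log units; within the scatter). For compound 4 the estimated value is 105 ug/mL, with an expected range from 55 ug/mL to 190 ug/mL.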

Compound 4, half-maximal inhibitory concentration: 86.4 ug/mL
Compound 4: the middle estimate sits 1.2-fold (0.08 log units) above what was measured; the measured number falls inside the stated range.
By their numbers in this assay, from the lowest: compounds 4, 2, 1 and 3 (each within the scatter of the next).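

In this assay, the exchange at this carbon, opposite the ring nitrogen, now covers a group with a hydroxyl and neither an amino nor a nitro group, and the outcome is a 1.1-fold lower number from compound 2 to compound 4 (0.03 log units; within the scatter) even though the entering group has fewer heavy atoms and fewer hydrogen-bond acceptors than the one it replaces. Set against the other two groups, 4-hydroxyphenyl gives a 1.4-fold lower number from compound 3 to compound 4 (0.14 log units; within the scatter) and a 1.3-fold lower number from compound 1 to compound 4 (0.11 log units; within the scatter) in this assay, so all the exchanges among these four groups at this carbon stay within the scatter. Nothing shown here explains these closely similar numbers.

Every compound shown carries an aromatic carbon ring at this carbon, so whether an amine, a carboxylic acid or a saturated chain attached there directly would give a step beyond the scatter remains open. The methyl group on the shared core is the same throughout, and what a longer chain in its place would do is equally unknown.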